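A few compounds are considered here, and "the series" means these few. Any claim that something is new, unique, unknown or untested is made for them only; others in the source may bear on it.

Working notes on the series.

For the measured compounds named here, compound 1 `COc1ccc([C@@H]2CC(=O)c3c(O)cc(OCc4cn(Cc5ccc(F)cc5)nn4)cc3O2)cc1O` is one of two compounds measured in a functional assay on RAW264.7 cells (Mus musculus) for inhibition, read by Griess assay, with stated times of 2 h and 24 h; a higher number here means a weaker inhibitor, a lower number a stronger inhibitor; in this assay compound 1 gives 15100 nM. Compound 2 `COc1ccc([C@@H]2C/C(=N\O)c3c(O)cc(OCc4cn(C5CCCC5)nn4)cc3O2)cc1O` differs from compound 1 in more than one place and is not a single step; in this assay compound 2 gives 6880 nM. Compound 1 thus stands at the highest of the two numbers, with compound 2 as its nearest neighbour at a lower number beyond the scatter.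

Compound 3 `C=CCn1cc(COc2cc(O)c3c(c2)O[C@H](c2ccc(OC)c(O)c2)CC3=O)nn1` is not yet measured in this assay. Against compound 1 the change is vinyl in place of 4-fluorophenyl on a saturated chain carbon bound to an aromatic nitrogen. Going by the values given here, no measured pair in the set shows this change alone, so there is no observed step to lean on; the only comparison, compound 1 against compound 2, mixes several changes and cannot be separated.

The expectation for the step from compound 1 to compound 3 is a small one, a 1.2-fold higher number from compound 1 to compound 3 (0.08 log units; within the scatter), not clearly beyond the scatter in either direction, since nothing measured here speaks for a larger move. Compound 3 is accordingly estimated at 18000 nM, with a range from 7000 nM to 45000 nM.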

Compound 3, half-maximal inhibitory concentration: 13800 nM
Beside the measured number, compound 3's estimate is 1.3-fold (0.12 log units) above it; the measured number falls inside the stated range.
By their numbers in this assay, from the lowest: compounds 2, 3 and 1 (each within the scatter of the next, the first and the last beyond it).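

In this assay, for the compounds shown here, the first single-place step replaces 4-fluorobenzyl with allyl on the shared core and gives a 1.1-fold lower number from compound 1 to compound 3 (0.04 log units; within the scatter). On a saturated chain carbon bound to an aromatic nitrogen, the six-membered aromatic ring of carbon only and the fluorine can therefore leave, with vinyl entering in place of 4-fluorophenyl, and the two numbers remain within the scatter of each other, so for this pair the 4-fluorophenyl group is not required for the level of inhibition seen with compound 1. No supporting data are available to explain this result.

On these data alone, whether a group of another kind at this place, such as a primary amine, a carboxylic acid or a longer alkyl chain, would give a step beyond the scatter remains open. Also open is whether the exchange of 4-fluorobenzyl for allyl would read the same way on the core of compound 2, since the single step shown here comes from the core of compound 1 alone.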